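The compounds below may be only part of what the source reports. "The series", "measured", "known", "first", "only" and "open" are said of these compounds alone.

The measured compounds:
Compound 1 `COc1ccc(C2=C(c3ccc(SC)cc3)CC3CCCN3C2=O)cc1O` gives > 100000 nM in a functional assay on SK-OV-3 cells (Homo sapiens) for cytotoxicity (on this read-out higher numbers stand for weaker inhibition of growth and lower numbers for stronger inhibition of growth), which is a limit of the assay rather than a number (the limit of > 100000 nM in this assay, at which 1 of the 3 values shown sits).
Compound 2 `CSc1ccc(C2=C(c3ccc(C)c(C)c3)C(=O)N3CCCC3C2)cc1` gives 300 nM in this assay.
Compound 3 `CSc1ccc(C2=C(c3ccc(F)c(C)c3)C(=O)N3CCCC3C2)cc1` gives 300 nM in this assay.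

Compound 1 therefore stands only at a limit; no exact number is known for it. Compound 4 `CSc1ccc(C2=C(c3ccc(C)cc3)C(=O)N3CCCC3C2)cc1` differs from compound 1 by 4-methylphenyl in place of 3-hydroxy-4-methoxyphenyl on a double-bonded ring carbon. Two measured steps start from compound 1 and exchange the same 3-hydroxy-4-methoxyphenyl group for a differently substituted phenyl group: an at least 330-fold lower number from compound 1 to compound 2 (2.52 log units; beyond the scatter) and an at least 330-fold lower number from compound 1 to compound 3 (2.52 log units; beyond the scatter). Between those two products, no change at the digits printed from compound 2 to compound 3 (within the scatter). The change to compound 4 is of the same kind, so a large step to a lower number is expected, an at least 250-fold lower number from compound 1 to compound 4 (2.39 log units; beyond the scatter). Compound 4 is estimated at 400 nM, within a range from 120 nM to 2000 nM.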

Compound 4, concentration for 50% growth inhibition: 9000 nM
Compound 4: the middle estimate sits 23-fold (1.35 log units) below what was measured, outside the stated range (above it).
By their numbers in this assay, from the lowest: compounds 2 and 3 (each within the scatter of the next); then compound 4. At a limit, above all of these: compound 1.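

Taking one methyl off the 3,4-dimethylphenyl group weakens growth inhibition sharply (a 30-fold higher number from compound 2 to compound 4 (1.48 log units; beyond the scatter)), and 4-methylphenyl in place of 4-fluoro-3-methylphenyl does the same (a 30-fold higher number from compound 3 to compound 4 (1.48 log units; beyond the scatter)), so at this position a single substituent on the phenyl ring counts for much. Yet 4-methylphenyl still improves on 3-hydroxy-4-methoxyphenyl (an at least 11-fold lower number from compound 1 to compound 4 (1.04 log units; beyond the scatter)), so only part of the gain is lost. That last step rests on a limit of the assay for compound 1: the limit of > 100000 nM in this assay, at which 1 of the 4 values shown sits.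

From the compounds shown here alone, whether a chloro group or an amine in place of that methyl would keep the lower number stays open. So does whether the 4-methyl group is needed at all.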